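An ethyl for an acetyl at the assay limit

This account rests on a few compounds, and the source may have more. Where it says the series, first, only, none or still open, it means among the compounds named here.

In a functional assay on DU-145 cells (Homo sapiens) for cytotoxicity, read by sulforhodamine B assay, with a stated time of 48 h (a lower number here means that less compound is tolerated, a higher number that more compound is tolerated), each entry below is a limit and not a number:
- Compound 1 (`N#Cc1ccc(Nc2nc(Oc3ccnc4ccccc34)nc(N3CCN(c4ccc(F)cc4)CC3)n2)cc1C(F)(F)F`) gives > 100000 nM (a limit)
- Compound 2 (`CC(=O)N1CCN(c2nc(Nc3ccc(C#N)c(C(F)(F)F)c3)nc(Oc3ccnc4ccccc34)n2)CC1`) gives > 100000 nM (a limit)
- Compound 3 (`CC1CC(C)CN(c2nc(Nc3ccc(C#N)c(C(F)(F)F)c3)nc(Oc3ccnc4ccccc34)n2)C1`) gives > 100000 nM (a limit)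

Compound 2 stands only at a limit, and so do the two other values, as the limit of > 100000 nM in this assay, at which 3 of the 3 values shown sit, records. Compound 4 (`CCN1CCN(c2nc(Nc3ccc(C#N)c(C(F)(F)F)c3)nc(Oc3ccnc4ccccc34)n2)CC1`) has not yet been measured. It carries ethyl in place of acetyl on an amine nitrogen in a ring, and the counted difference from compound 2 is ethyl in place of acetyl on an amine nitrogen in a ring.

Among the measured compounds shown here, two measured steps bear on this change. The closer one is a step that the two limits leave unreadable from compound 1 to compound 2, with acetyl in place of 4-fluorophenyl on an amine nitrogen in a ring. The other is a step that the two limits leave unreadable from compound 2 to compound 3, with 3,5-dimethylpiperidin-1-yl in place of 4-acetylpiperazin-1-yl on an aromatic carbon. Neither has a size that can be read.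

Because of the limit of > 100000 nM in this assay, at which 3 of the 3 values shown sit, and a step that the two limits leave unreadable from compound 1 to compound 2 no step beyond the scatter is expected in this assay, and no direction can be given. The expected change is a number no higher from compound 2 to compound 4 (the limit leaves the size open). For compound 4 the estimate is 100000 nM, with an expected range from 30000 nM to 150000 nM.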

Compound 4, concentration lethal to 50% of the cells: > 100000 nM
Compound 4: no number, only a limit (the forecaster's own chance of this, stated with the estimate: 80%); the middle value sits exactly at the limit.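

In this assay compound 4 gives > 100000 nM, which is a limit and not a number. The steps joining compound 4 to compound 1, compound 2 and compound 3 cannot be read because of this shared limit: the limit of > 100000 nM in this assay, at which 4 of the 4 values shown sit.

The compounds shown leave open whether ethyl, acetyl or 4-fluorophenyl on the ring nitrogen makes any difference in this assay, and how large it would be.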